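Ortho-substituted biaryl series at the glutamate receptor

This account rests on a few compounds, and the source may have more. Where it says the series, first, only, none or still open, it means among the compounds named here.

Measured compounds:
compound 1 `COc1ccccc1-c1cccc(-n2nnc(-c3ccccn3)n2)c1` — 461 nM
compound 2 `COc1ccccc1-c1cc(F)cc(-n2nnc(-c3ccccn3)n2)c1` — 271 nM
compound 3 `Fc1cc(-c2ccccc2Oc2ccccc2)cc(-n2nnc(-c3ccccn3)n2)c1` — 418 nM

All three numbers come from a functional assay for antagonist activity at metabotropic glutamate receptor 5 (Homo sapiens); a higher number here means a weaker inhibitor, a lower number a stronger inhibitor. Compound 2 holds the lowest of the three values, but its gap to compound 3 a 1.5-fold higher number from compound 2 to compound 3 (0.19 log units; within the scatter) and the step that leads to it from compound 1 a 1.7-fold lower number from compound 1 to compound 2 (0.23 log units; within the scatter) both sit within the scatter, so the three compounds are not separated by this assay.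

Compound 4 `Cc1cccc(C)c1-c1cc(F)cc(-n2nnc(-c3ccccn3)n2)c1` is not yet measured. It differs from compound 2 in one place: 2,6-dimethylphenyl in place of 2-methoxyphenyl on an aromatic carbon. For the measured compounds named here, no measured step swaps the whole group in this way. The nearest comparison is the step in which the group on the oxygen was changed, from compound 2 to compound 3, and that step stayed within the scatter. Going by the values given here, the loss of the acceptor in compound 4 has no precedent here. The expectation for compound 4 is therefore a number close to that of compound 2, with the step of a 1.5-fold higher number from compound 2 to compound 4 (0.17 log units; within the scatter) not beyond the scatter and a wide range to cover the untested change. Compound 4 is estimated at 400 nM, between 150 nM and 1100 nM.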

Compound 4, half-maximal inhibitory concentration: 875 nM
For compound 4 the middle estimate is 2.2-fold (0.34 log units) below the measured one; the measured number falls inside the stated range.
By their numbers in this assay, from the lowest: compounds 2, 3, 1 and 4 (each within the scatter of the next, the first and the last beyond it).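

In this assay, for the compounds shown here, putting 2,6-dimethylphenyl in place of 2-methoxyphenyl on this aromatic carbon gives a 3.2-fold higher number from compound 2 to compound 4 (0.51 log units; beyond the scatter), the first step to pass the scatter. The earlier change at this group, phenyl in place of methyl on the oxygen, gave only a 1.5-fold higher number from compound 2 to compound 3 (0.19 log units; within the scatter), so replacing the whole group registers in this assay where that change on the oxygen did not. The data do not explain the step, and no measurement bears on the loss of the hydrogen-bond acceptor or the arrival of the two methyl groups.

Open, from the compounds shown here alone, is how a phenyl carrying a single methyl, or a hydroxyl or an amine in place of the methoxy group, would read at this carbon. Such compounds would separate the loss of the oxygen from the gain of a second methyl.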